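A few compounds are considered here, and "the series" means these few. Any claim that something is new, unique, unknown or untested is made for them only; others in the source may bear on it.

Compound 1 `CCCCCCCCCCc1cn(C[C@H](O)[C@H]2OC(=O)C(OCc3ccccc3)=C2OCc2ccccc2)nn1` and compound 2 `O=C1O[C@H]([C@@H](O)Cn2cc(-c3cc(F)cc(F)c3)nn2)C(OCc2ccccc2)=C1OCc1ccccc1` share one core and differ only in the group on an aromatic carbon of the five-membered ring. In a functional assay on HCT-116 cells (Homo sapiens) for antiproliferative activity, read by MTT assay, with a stated time of 72 h (a lower number here means a stronger inhibitor, a higher number a weaker inhibitor), compound 1 gives 28800 nM, and compound 2 gives 48200 nM. Of the two numbers shown, the one for compound 2 is the greater, yet the step of a 1.7-fold higher number from compound 1 to compound 2 (0.22 log units; within the scatter) lies within the scatter, so neither compound can be called the weaker. Compound 3 `Cc1ccc(S(=O)(=O)NCc2cn(C[C@H](O)[C@H]3OC(=O)C(OCc4ccccc4)=C3OCc3ccccc3)nn2)cc1` has not yet been measured. It differs from compound 2 in that ((((4-methylphenyl)sulfonyl)amino)methyl in place of 3,5-difluorophenyl on an aromatic carbon). Going by the values given here, the only measured step that bears on this position is a 1.7-fold higher number from compound 1 to compound 2 (0.22 log units; within the scatter), and it moved the number little despite a large exchange of groups. Because a 1.7-fold higher number from compound 1 to compound 2 (0.22 log units; within the scatter) stayed within the scatter, compound 3 is expected to show a step of only a 1.2-fold lower number from compound 2 to compound 3 (0.08 log units; within the scatter) in this assay, none beyond the scatter. The estimate for compound 3 is 40000 nM, with a range from 15000 nM to 110000 nM.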

Compound 3, half-maximal inhibitory concentration: 13100 nM
Compound 3: the middle estimate sits 3.1-fold (0.48 log units) above what was measured, and the stated range ends above it.
By their numbers in this assay, from the lowest: compound 3; then compounds 1 and 2 (each within the scatter of the next).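

In this assay, the position on an aromatic carbon of the five-membered aromatic ring can move the number beyond the scatter, which the exchange of decyl for 3,5-difluorophenyl had not shown. The (((4-methylphenyl)sulfonyl)amino)methyl group gives a 3.7-fold lower number from compound 2 to compound 3 (0.57 log units; beyond the scatter), and against the decyl side it gives a 2.2-fold lower number from compound 1 to compound 3 (0.34 log units; beyond the scatter), so it stands apart from both earlier groups, though both steps are modest. Unlike the 3,5-difluorophenyl it replaces, this group has 1 hydrogen-bond donor and 2 hydrogen-bond acceptors, but nothing here ties those counts to the step, and no measurement bearing on its cause is available.

The compounds shown do not tell which part of the new group goes with the lower number. An amide in place of the sulfonyl, or an unsubstituted phenyl in place of the 4-methylphenyl, would separate those parts, and an amine or a carboxylic acid at this position remains an open case.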